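The compounds below may be only part of what the source reports. "The series", "measured", "known", "first", "only" and "open" are said of these compounds alone.

Measured so far:
- compound 1, `NS(=O)(=O)c1ccc(NC(=S)Nc2ccc3ncnc(Nc4cccc(C(F)(F)F)c4)c3c2)cc1`: 21700 nM
- compound 2, `NS(=O)(=O)c1ccc(NC(=S)Nc2ccc3ncnc(Nc4cccc(Cl)c4F)c3c2)cc1`: 13100 nM

Both numbers come from a functional assay on A-431 cells (Homo sapiens) for antiproliferative activity, read by MTT assay, with a stated time of 72 h; on this read-out higher numbers stand for weaker inhibition and lower numbers for stronger inhibition. In this assay, going by the values given here, compound 1 gives 21700 nM and compound 2 gives 13100 nM; the only measured step, a 1.7-fold lower number from compound 1 to compound 2 (0.22 log units; within the scatter), exchanges the whole aryl group on the amine nitrogen and stays within the scatter. Compound 2 therefore carries the lowest of the two numbers, with compound 1 sitting within the scatter of it, so no order between the two can be claimed.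

Compound 3, `NS(=O)(=O)c1ccc(NC(=S)Nc2ccc3ncnc(Nc4cccc(Cl)c4)c3c2)cc1`, is not yet measured. It differs from compound 2 by hydrogen in place of fluoro on an aromatic carbon. Among the compounds with values here, no measured step touches a single fluoro at this position; the one step available, from compound 1 to compound 2, is both structurally broader and within the scatter, so it offers no direction for this smaller change. Against that background the expectation for compound 3 is a number close to that of compound 2, with no step beyond the scatter in either direction. The step implied by this expectation is a 1.2-fold higher number from compound 2 to compound 3 (0.09 log units; within the scatter). The estimate for compound 3 in this assay is 16000 nM, with a range from 6000 nM to 40000 nM.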

Compound 3, half-maximal inhibitory concentration: 15000 nM
Compound 3: the middle estimate sits 1.1-fold (0.03 log units) above what was measured; measured number inside the range.
By their numbers in this assay, from the lowest: compounds 2, 3 and 1 (each within the scatter of the next).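

In this assay, going by these compounds alone, taking away the fluoro and leaving hydrogen on the aromatic carbon ortho to a chloro group gives a 1.1-fold higher number from compound 2 to compound 3 (0.06 log units; within the scatter), the first reading of this single atom on its own, and at this position the change stays within the scatter. Chloro in place of trifluoromethyl on an aromatic carbon gives a 1.4-fold lower number from compound 1 to compound 3 (0.16 log units; within the scatter), so the broader exchange of the whole aryl group now divides into two single changes, neither of which leaves the scatter. Nothing available on these compounds offers an explanation for the size of these steps.

Going by these compounds, the three compounds carry only chloro, fluoro and trifluoromethyl on this aryl group, so it remains open whether a methoxy group, a nitrile or an amine there would give a step beyond the scatter. Also open, on these data alone, is whether a change away from this aryl group, such as a carboxylic acid in place of the sulfonamide, would give such a step in this assay.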